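This account rests on a few compounds, and the source may have more. Where it says the series, first, only, none or still open, it means among the compounds named here.

Compound 1 `N=S1(=O)CC(Nc2nonc2/C(=N/O)Nc2ccc(F)c(Br)c2)C1` — 208 nM
Compound 2 `O=S(=O)(CCNc1nonc1/C(=N/O)Nc1ccc(F)c(Br)c1)NO` — 126 nM
Compound 3 `NS(=O)(=O)CCCNc1nonc1/C(=N/O)Nc1ccc(F)c(Br)c1` — 126 nM

In an assay on isolated protein for inhibition of Indoleamine 2,3-dioxygenase 1 (Homo sapiens), read by fluorescence, with a stated time of 60 min (on this read-out higher numbers stand for weaker inhibition and lower numbers for stronger inhibition), compound 3 stands level with compound 2 at the digits shown, and together they hold the lowest of the three numbers, though every step among these compounds lies within the usual scatter. Its nearest neighbour is compound 2, no change at the digits printed from compound 2 to compound 3 (within the scatter); its furthest is compound 1, a 1.7-fold lower number from compound 1 to compound 3 (0.22 log units; within the scatter). Compound 4 `NS(=O)(=O)CCONc1nonc1/C(=N/O)Nc1ccc(F)c(Br)c1` carries 2-sulfamoylethoxy in place of 3-sulfamoylpropyl on a nitrogen on an aromatic ring. Among the compounds with values here, no measured step alters a chain atom in this way; the steps that bear on it exchange whole side groups on that nitrogen, a 1.7-fold lower number from compound 1 to compound 2 (0.22 log units; within the scatter) and a 1.7-fold lower number from compound 1 to compound 3 (0.22 log units; within the scatter), both small. Compound 4 is therefore expected to sit close to compound 3, a 1.2-fold higher number from compound 3 to compound 4 (0.08 log units; within the scatter). The estimate for compound 4 is 150 nM, with a range from 60 nM to 400 nM.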

Compound 4, half-maximal inhibitory concentration: 87 nM
The estimate for compound 4 lay 1.7-fold (0.24 log units) above the measured number; low and high end bracket the measured number.
By their numbers in this assay, from the lowest: compounds 4, 2, 3 and 1 (each within the scatter of the next, the first and the last beyond it).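

Putting 2-sulfamoylethoxy in place of 3-sulfamoylpropyl on a nitrogen on an aromatic ring is tolerated (a 1.4-fold lower number from compound 3 to compound 4 (0.16 log units; within the scatter)), and the same holds against the 2-(hydroxysulfamoyl)ethyl group (a 1.4-fold lower number from compound 2 to compound 4 (0.16 log units; within the scatter)). Within the data shown here, compound 4 also provides the first step in this set to clear the scatter, a modest one (a 2.4-fold lower number from compound 1 to compound 4 (0.38 log units; beyond the scatter)). Nothing measured here accounts for these numbers. Still open, as far as these compounds go, is how an amine or a carboxylic acid in place of the sulfamoyl group would read, and how a longer chain would compare.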